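Halogen swap on the aryl urea, fluoro to iodo

This account rests on a few compounds, and the source may have more. Where it says the series, first, only, none or still open, it means among the compounds named here.

Measured so far:
compound 1, `CC(C)c1cccc(NC(=O)N[C@@H](C)c2ccccc2)c1`, 84% in an ADME assay on the whole organism with Oryza sativa as the target, tested at 1 uM; a higher number here means a weaker effect of the compound at the concentration tested, a lower number a stronger effect
compound 2, `C[C@H](NC(=O)Nc1cccc(F)c1)c1ccccc1`, 94%

Compound 2 holds the highest of the two numbers recorded in this assay; its nearest neighbour is compound 1, and the gap a number 10 percentage points higher from compound 1 to compound 2 (within the scatter) is within the scatter, so the two compounds cannot be ranked against each other. For the measured compounds named here, that single step, fluoro in place of isopropyl on an aromatic carbon, is the only change measured.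

Compound 3, `C[C@H](NC(=O)Nc1cccc(I)c1)c1ccccc1`, has not yet been tested. It differs from compound 2 by iodo in place of fluoro on an aromatic carbon, the new group sitting on an aromatic carbon of a six-membered aromatic ring of carbon only, meta to a large group. Going by the values given here, no measured step concerns an iodo group, so nothing bears directly on this change. Among the compounds with values here, the one step known, from isopropyl to fluoro at the same position, stayed within the scatter, which points to a modest effect of substituents here. Compound 3 is therefore expected to stay close to compound 2, with a step of a number 6 percentage points lower from compound 2 to compound 3 (within the scatter) not beyond the scatter, and an estimated 88%, range 70% to 100%.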

Compound 3, a percentage reported as activity, at one concentration (the size of the read-out at that concentration, not a potency): 95%
Compound 3: the middle estimate sits 7 percentage points below what was measured, within the range that was stated.
By their numbers in this assay, from the lowest: compounds 1, 2 and 3 (each within the scatter of the next, the first and the last beyond it).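

In this assay, for the compounds shown here, the exchange of fluoro for iodo gives a number 1 percentage points higher from compound 2 to compound 3 (within the scatter) and so leaves the two halogens indistinguishable at this position on the aromatic ring, even though they are the only pair of halogens compared here. Set against the isopropyl group, iodo gives a number 11 percentage points higher from compound 1 to compound 3 (beyond the scatter) as the first step in the series to pass the scatter, a modest separation in which the higher number marks the weaker effect for compound 3. Compound 2 remains within the scatter of both neighbours, so the three compounds show one modest separation between the isopropyl and iodo compounds and no graded order that would include fluoro.

As far as these compounds go, whether an amine, a carboxylic acid or a longer alkyl chain in this same place on the aromatic ring would lower the number further than isopropyl does remains open, as does the effect of any change to the urea or to the chiral phenylethyl part of the shared core. Nothing available explains why isopropyl and iodo separate here while the other two steps do not.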